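Adding a Methoxy Group: From Compound 1 to Compound 3

The source may report more compounds than this note shows. Statements on the series, on what has been measured and on what is new or still open speak of the compounds shown alone.

Compound 1 `COc1ccc(-c2cc(/C=C/C(=O)c3ccc(N)cc3)[nH]n2)cc1` gives -74% in a functional assay on COLO 205 cells (Homo sapiens) for cytotoxicity, read by sulforhodamine B assay, with a stated time of 48 h, tested at 100 uM; a higher number here means a weaker effect of the compound at the concentration tested, a lower number a stronger effect. Among the two numbers obtained so far it stands highest, yet compound 2 `COc1ccc(C(=O)/C=C/c2cc(-c3cc(OC)c(OC)c(OC)c3)n[nH]2)cc1` gives -81%, which lies within the scatter of the value of compound 1, so the two cannot be ordered. Compound 3 `COc1ccc(-c2cc(/C=C/C(=O)c3ccc(N)cc3)[nH]n2)cc1OC` differs from compound 1 by methoxy in place of hydrogen on an aromatic carbon. Among the measured compounds shown here, no step between measured compounds exists to guide the expectation, so no step beyond the scatter is assumed. Compound 3 is expected to give -75%, with a range from -92% to -55%. This estimate means an expected step of a number 1 percentage points lower from compound 1 to compound 3 (within the scatter), of a size no larger than the usual scatter.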

Compound 3, a percentage reported as activity, at one concentration (the size of the read-out at that concentration, not a potency): -78%
Compound 3: middle estimate off by 3 percentage points, on the high side, and the stated range covers the measured number.
By their numbers in this assay, from the lowest: compounds 2, 3 and 1 (each within the scatter of the next).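

In this assay, methoxy in place of hydrogen on an aromatic carbon, ortho to a methoxy group and meta to a large group, gives a step of a number 4 percentage points lower from compound 1 to compound 3 (within the scatter), so this first step read at this position leaves compound 1 and compound 3 indistinguishable. The added methoxy is thus tolerated here at this single concentration, without a separable change in the read-out. No measurement available here bears on why this is so. On these data alone, whether a hydroxy group or a chlorine atom at this place would give a step beyond the scatter remains open, as does the outcome of replacing the amine with a carboxylic acid.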